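Replacing a methoxy-bearing ring with a dichloro-bearing one

The compounds below may be only part of what the source reports. "The series", "measured", "known", "first", "only" and "open" are said of these compounds alone.

Three measured compounds share one core and differ only in the group on an amide-type nitrogen. Compound 1 `O=C(Nc1ccccc1)Nc1nnc(Sc2ncnc3scc(-c4ccncc4)c23)s1` is the unsubstituted parent; in a functional assay on HUVEC cells (Homo sapiens) for antiproliferative activity, read by MTT assay, with a stated time of 48 h (a lower number here means a stronger inhibitor, a higher number a weaker inhibitor), compound 1 gives 19300 nM. Compound 2 `O=C(Nc1cccc(Cl)c1)Nc1nnc(Sc2ncnc3scc(-c4ccncc4)c23)s1` has chloro in place of hydrogen on an aromatic carbon, and compound 2 gives 21000 nM. Compound 3 `COc1ccc(NC(=O)Nc2nnc(Sc3ncnc4scc(-c5ccncc5)c34)s2)cc1` has methoxy in place of hydrogen on an aromatic carbon, and compound 3 gives 16900 nM. Compound 3 has the smallest of the three numbers, but the steps of a 1.1-fold lower number from compound 1 to compound 3 (0.06 log units; within the scatter) and a 1.2-fold lower number from compound 2 to compound 3 (0.09 log units; within the scatter) are both within the scatter, so the three compounds cannot be told apart on these data.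

Compound 4 `O=C(Nc1ccc(Cl)c(Cl)c1)Nc1nnc(Sc2ncnc3scc(-c4ccncc4)c23)s1` is reached from compound 3 by 3,4-dichlorophenyl in place of 4-methoxyphenyl on an amide-type nitrogen. Among the measured compounds shown here, two measured steps bear on this change: a 1.1-fold higher number from compound 1 to compound 2 (0.04 log units; within the scatter), which tests a single chloro on the ring, and a 1.1-fold lower number from compound 1 to compound 3 (0.06 log units; within the scatter), which tests the methoxy that now leaves. Neither moved the number beyond the scatter. For the measured compounds named here, a second chloro on the same ring has no measured counterpart here. The expected step of a 1.1-fold higher number from compound 3 to compound 4 (0.05 log units; within the scatter) is therefore none beyond the scatter. Compound 4 is estimated at 19000 nM, with a range from 9000 nM to 40000 nM.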

Compound 4, half-maximal inhibitory concentration: 7800 nM
Estimate against measurement, compound 4: 2.4-fold (0.39 log units) above; the whole stated range lies above it.
By their numbers in this assay, from the lowest: compound 4; then compounds 3, 1 and 2 (each within the scatter of the next).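

In this assay, among the compounds shown here, the group on this amide-type nitrogen proves able to move the number beyond the scatter, which no step among compound 1, compound 2 and compound 3 did: the 3,4-dichlorophenyl group gives a modest change against the 4-methoxyphenyl group (a 2.2-fold lower number from compound 3 to compound 4 (0.34 log units; beyond the scatter)) and against the plain phenyl group (a 2.5-fold lower number from compound 1 to compound 4 (0.39 log units; beyond the scatter)). The comparison with the single-chloro ring is the most telling, since one further chloro on that ring gives a modest step beyond the scatter (a 2.7-fold lower number from compound 2 to compound 4 (0.43 log units; beyond the scatter)), whereas the first chloro stayed within it (a 1.1-fold higher number from compound 1 to compound 2 (0.04 log units; within the scatter)). Nothing given here offers an explanation for this difference.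

The compounds shown leave open whether chlorine itself matters or whether any two groups on this ring would give a similar step, a question that a ring bearing two fluoro groups, two methyl groups or a trifluoromethyl group could address. They also leave open how this position would respond to an amine or a carboxylic acid on the ring.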